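Chloro to bromo on the aryl ring of compound 1

The source may hold more compounds than are shown below. What is called first, only, known or untested is meant among the compounds shown, and "the series" means these compounds.

Measured so far in a functional assay on HepG2 cells (Homo sapiens) for inhibition, read by sulforhodamine B assay, with a stated time of 72 h; a higher number here means a weaker inhibitor, a lower number a stronger inhibitor:
- compound 1, `CC(c1ccc(-c2ccccc2)c(F)c1)c1nnc2n1N=C(c1ccc(Cl)cc1)CS2`: 6700 nM
- compound 2, `CC(c1ccc(-c2ccccc2)c(F)c1)c1n[nH]c(=S)n1N`: 21400 nM

Compound 1 holds the lowest of the two numbers in this assay. Compound 2, the open aminotriazolethione lacking the fused second ring, gives 21400 nM, a gap from compound 1 that lies beyond the usual scatter, so compound 1 stands as the stronger inhibitor of the two on what is in hand.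

Compound 3, `CC(c1ccc(-c2ccccc2)c(F)c1)c1nnc2n1N=C(c1ccc(Br)cc1)CS2`, is the next structure to be placed in this assay. It departs from compound 1 at a single point: bromo in place of chloro on an aromatic carbon. Going by the values given here, no measured pair yet isolates this change, so there is no step to lean on directly. A halogen swap of this kind is expected to move the number little; the step of a 1.2-fold lower number from compound 1 to compound 3 (0.06 log units; within the scatter) is estimated to stay within the scatter, with no clear direction.

Compound 3 is therefore expected to give about 5800 nM, in the range 2600 nM to 13000 nM.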

Compound 3, half-maximal inhibitory concentration: 3700 nM
For compound 3 the middle estimate is 1.6-fold (0.20 log units) above the measured one, and the stated range covers the measured number.
By their numbers in this assay, from the lowest: compounds 3 and 1 (each within the scatter of the next); then compound 2.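

In this assay, going by these compounds alone, the change from 4-chlorophenyl to 4-bromophenyl gives a 1.8-fold lower number from compound 1 to compound 3 (0.26 log units; within the scatter) and is the first single-place step. At this aromatic carbon, bromo can therefore stand in place of chloro with no shift that can be told from the scatter, and compound 3 and compound 1 cannot be separated on these numbers. Nothing available bears on why the two halogens read alike here.

The compounds shown leave open how a methoxy group, an amine or a carboxylic acid in place of the halogen would read in this assay. From the compounds shown here alone, with only chloro and bromo to compare, it also remains open whether any change at this position can move the number beyond the scatter.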